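A few compounds are considered here, and "the series" means these few. Any claim that something is new, unique, unknown or untested is made for them only; others in the source may bear on it.

Series notes. Compound 1 `O=C(C1CCC(F)(F)CC1)N1CC(c2nc(-c3cccc(Cl)c3)no2)C1` carries a 4,4-difluorocyclohexyl group on the carbonyl carbon attached to the shared core. In an assay on HEK293 cells for negative allosteric modulation of metabotropic glutamate receptor 5 (Homo sapiens), read by FLIPR (on this read-out higher numbers stand for weaker inhibition and lower numbers for stronger inhibition), compound 1 gives only a limit, > 10000 nM, so its standing is known only as the limit of > 10000 nM in this assay, at which 1 of the 3 values shown sits. The two compounds with a sulfonyl group in place of the carbonyl sit elsewhere on the scale: compound 2 `O=S(=O)(c1ccc(Cl)cc1)N1CC(c2nc(-c3cccc(Cl)c3)no2)C1` gives 170 nM in this assay, and compound 3 `Cc1ccc(S(=O)(=O)N2CC(c3nc(-c4cccc(C)c4)no3)C2)cc1` gives 670 nM. Compound 4 `O=C(N1CCCCCC1)N1CC(c2nc(-c3cccc(Cl)c3)no2)C1` keeps the carbonyl of compound 1 and changes the group on it: azepan-1-yl in place of 4,4-difluorocyclohexyl on a carbonyl carbon. For the measured compounds named here, no measured pair isolates this change, so the direction is open. The expected step of an at least 1.2-fold lower number from compound 1 to compound 4 (0.09 log units; that floor lies within the scatter) is none beyond the scatter, with a fair chance of another limit. Compound 4 is therefore expected near 8000 nM, within 2000 nM to 30000 nM.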

Compound 4, half-maximal inhibitory concentration: > 10000 nM
Compound 4: a limit, no number; the forecaster's own chance of this, stated with the estimate: 50%; middle value at least 1.2-fold (0.09 log units) away from the limit.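

For the compounds shown here, compound 1 and compound 4 each give only a limit, not a number, in this assay, so no step between them can be read: the limit of > 10000 nM in this assay, at which 2 of the 4 values shown sit.
The compounds shown leave open whether azepan-1-yl or 4,4-difluorocyclohexyl on a carbonyl carbon gives the stronger inhibition.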